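Bromophenyl isomers in the series: compound 2 to compound 3

The source may hold more compounds than are shown below. What is called first, only, known or untested is meant among the compounds shown, and "the series" means these compounds.

In a functional assay on A549 cells (Homo sapiens) for inhibition, read by MTT assay, with a stated time of 24 h (on this read-out lower numbers stand for stronger inhibition of growth and higher numbers for weaker inhibition of growth), compound 1 `COc1ccc(C(=O)n2c(-c3cn(C)c4ccccc34)nc3ccccc32)cc1` gives 10400 nM and compound 2 `Cn1cc(-c2nc3ccccc3n2C(=O)c2ccccc2Br)c2ccccc21` gives 43200 nM. Compound 2 therefore holds the higher of the two numbers, and so the weaker growth inhibition so far.

Compound 3 `Cn1cc(-c2nc3ccccc3n2C(=O)c2cccc(Br)c2)c2ccccc21` is the next to be read. The change from compound 2 is 3-bromophenyl in place of 2-bromophenyl on a carbonyl carbon, with the same atoms joined differently.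

Going by the values given here, only one measured step bears on this, a 4.2-fold higher number from compound 1 to compound 2 (0.62 log units; beyond the scatter), a modest step that put 2-bromophenyl in place of 4-methoxyphenyl at the same carbonyl carbon. That step replaces the group outright, so it says nothing direct about where the bromine sits. Among the compounds with values here, no measured pair separates the two bromophenyl forms.

A smaller change than that step is therefore expected, leaning toward a lower number but not clearly beyond the scatter. The estimated step is a 1.7-fold lower number from compound 2 to compound 3 (0.24 log units; within the scatter). For compound 3 the expected value is 25000 nM, with an estimated range of 9000 nM to 65000 nM.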

Compound 3, concentration for 50% growth inhibition: 34200 nM
Beside the measured number, compound 3's estimate is 1.4-fold (0.14 log units) below it, and the stated range covers the measured number.
By their numbers in this assay, from the lowest: compound 1; then compounds 3 and 2 (each within the scatter of the next).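

In this assay, the bromine isomers give a 1.3-fold lower number from compound 2 to compound 3 (0.10 log units; within the scatter) and so cannot be told apart at this carbonyl carbon: on these two compounds, 3-bromophenyl and 2-bromophenyl read as equivalent. The gap first seen with compound 2 also holds for the other isomer, at a 3.3-fold higher number from compound 1 to compound 3 (0.52 log units; beyond the scatter) as a modest step beyond the scatter, which leaves compound 1 as the strongest growth inhibitor of the three and shows that the 4-methoxyphenyl advantage is not confined to one bromophenyl form. Going by these compounds alone, no measurement on these compounds offers an account of either step.

Compound 1 differs from compound 2 and compound 3 in both the group on the ring and its place there, and the compounds shown cannot separate those two changes. Also open, on these data alone, is how an unsubstituted phenyl would read on this carbonyl carbon, and whether a ring carrying an amine or a carboxylic acid would stay near compound 1 or near the bromophenyl pair.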